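The source may report more compounds than this note shows. Statements on the series, on what has been measured and on what is new or still open speak of the compounds shown alone.

Measured so far in a functional assay on MDA-MB-435 cells (Homo sapiens) for cytotoxicity, read by MTT assay, with a stated time of 72 h; a higher number here means a weaker inhibitor, a lower number a stronger inhibitor

- compound 1 `CCCCCCCCCCCCCC(O)C1OC(=O)c2c(OC)cccc21` gives 12.3 ug/mL
- compound 2 `CCCCCCCCCCCCCC(=O)C1OC(=O)c2c(OC)cccc21` gives 8.7 ug/mL
- compound 3 `CCCCCCCCCCCCCCCc1cccc(OC)c1C(=O)OC` gives > 25 ug/mL

The values of compound 1 and compound 2 lie within the usual scatter of each other. The entry for compound 3 is a limit and not a number, and compound 3 stands at the limit of > 25 ug/mL in this assay, at which 1 of the 3 values shown sits, in this series. Compound 4 `CCCCCCCCCCCCCCC(Br)c1cccc(OC)c1C(=O)OC` is reached from it by one change, bromo in place of hydrogen on a saturated chain carbon bound to an aromatic carbon and a saturated chain carbon on that chain carbon. For the measured compounds named here, no measured pair shows this change, so any expectation in this assay is loose. The estimated at least 1.2-fold lower number from compound 3 to compound 4 (0.09 log units; that floor lies within the scatter) is a modest move toward stronger inhibition, and another limit reading remains quite possible. For compound 4 the expected value is 20 ug/mL with an estimated range from 8 ug/mL to 40 ug/mL in this read-out.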

Compound 4, half-maximal inhibitory concentration: > 25 ug/mL
Compound 4 was reported as a limit; the forecaster's own chance of this, stated with the estimate: 45%; at least 1.2-fold (0.09 log units) between middle value and limit.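

In this assay compound 3 and compound 4 both stand as limits, so no step between them can be read: the limit of > 25 ug/mL in this assay, at which 2 of the 4 values shown sit.

Going by these compounds, whether bromo in place of hydrogen on this saturated chain carbon shifts the value at all stays open.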